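A few compounds are considered here, and "the series" means these few. Any claim that something is new, unique, unknown or untested is made for them only; others in the source may bear on it.

Compound 3, `Cc1cc(N2CCN(C)CC2)c2ncc(CSCCc3ccccc3)n2c1`, belongs to a small set of analogues that share one core and a common side chain. In an ADME assay on HEL cells (Homo sapiens) for cytotoxicity, with a stated time of 3 days (on this read-out lower numbers stand for higher toxicity in this test and higher numbers for lower toxicity in this test), compound 1, `Cc1cc(-c2ccoc2)c2ncc(CSCCc3ccccc3)n2c1`, gives 64 ug/mL. For compound 2, `Cc1cc(N2CCCC2)c2ncc(CSCCc3ccccc3)n2c1`, only a limit of the assay is reported, > 100 ug/mL, and it is the single case of the limit of > 100 ug/mL in this assay, at which 1 of the 3 values shown sits. Among the compounds with values here, the change from compound 1 to compound 2 is the one measured step, an at least 1.5-fold higher number from compound 1 to compound 2 (0.19 log units; that floor lies within the scatter), and it shows no more than the usual scatter. In this assay, going by these compounds, compound 3 gives "not determined" (no result reported), so its standing on these numbers is unknown.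

Compound 4, `Cc1cc(-n2cccc2)c2ncc(CSCCc3ccccc3)n2c1`, differs from compound 3 in one place: 1H-pyrrol-1-yl in place of 4-methylpiperazin-1-yl on an aromatic carbon. The ring that enters is, like that in compound 1, a five-membered aromatic ring with one hetero atom, while the one that leaves resembles the saturated nitrogen ring of compound 2. Within the data shown here, since the only measured step, from compound 1 to compound 2, stayed within the scatter, there is no sign here that the choice of this ring shifts the cytotoxic concentration beyond it. Compound 4 is therefore expected to give about 75 ug/mL in this assay, with a likely range from 30 ug/mL to 150 ug/mL.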

Compound 4, half-maximal cytotoxic concentration: 26 ug/mL
For compound 4 the middle estimate is 2.9-fold (0.46 log units) above the measured one; the measured number lies below the stated range.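

In this assay, within the data shown here, this place on the shared core, an aromatic carbon two atoms from the ring nitrogen, now shows changes beyond the scatter, which the one earlier step did not: 1H-pyrrol-1-yl in place of furan-3-yl gives a clear shift (a 2.5-fold lower number from compound 1 to compound 4 (0.39 log units; beyond the scatter)), and 1H-pyrrol-1-yl in place of pyrrolidin-1-yl gives another (an at least 3.8-fold lower number from compound 2 to compound 4 (0.58 log units; beyond the scatter)). Both steps run the same way, so among the compounds with a usable reading, the swap to this ring goes with a lower number, meaning higher toxicity in this test, even against furan-3-yl, the other five-membered aromatic ring with one hetero atom. The size of the second step is only a floor, since the reading of compound 2 is a limit of the assay: the limit of > 100 ug/mL in this assay, at which 1 of the 4 values shown sits.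

The step between compound 3 and compound 4 cannot be read, since compound 3 has no number, and so the 4-methylpiperazin-1-yl group gives no comparison here. Going by these compounds, whether a phenyl ring, a morpholine ring or an open-chain dimethylamino group at this place would read nearer to compound 4 or to compound 1 remains open.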